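From prop-1-en-1-yl to pent-1-en-1-yl on compound 3

This account rests on a few compounds, and the source may have more. Where it says the series, first, only, none or still open, it means among the compounds named here.

Of the compounds shown here, three have been measured in a functional assay on A549 cells (Homo sapiens) for inhibition, read by MTT assay, with a stated time of 72 h; a higher number here means a weaker inhibitor, a lower number a stronger inhibitor. Compound 1 `C=C(Cl)C(=O)Nc1cc(Nc2nc3c(c(-c4cn(C)c5ccc(F)cc45)n2)CSCC3)c(OC)cc1N(C)CCN(C)C` gives 864 nM, compound 2 `COc1cc(N(C)CCN(C)C)c(NC(=O)C=C(C)C)cc1Nc1nc2c(c(-c3cn(C)c4ccccc34)n1)CS(=O)(=O)CC2` gives 787 nM, and compound 3 `C/C=C\C(=O)Nc1cc(Nc2nc3c(c(-c4cn(C)c5ccccc45)n2)CS(=O)(=O)CC3)c(OC)cc1N(C)CCN(C)C` gives 4260 nM. Compound 3 therefore has the highest number of the three, and its gaps to both others lie beyond the scatter.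

Compound 4 `CCC/C=C\C(=O)Nc1cc(Nc2nc3c(c(-c4cn(C)c5ccccc45)n2)CS(=O)(=O)CC3)c(OC)cc1N(C)CCN(C)C` differs from compound 3 in one place: ethyl in place of hydrogen on a saturated chain carbon bound to a double-bonded chain carbon. This is ethyl in place of hydrogen on a saturated chain carbon bound to a double-bonded chain carbon, so prop-1-en-1-yl becomes pent-1-en-1-yl.

Among the measured compounds shown here, only one measured step bears on this change: a 5.4-fold higher number from compound 2 to compound 3 (0.73 log units; beyond the scatter). It is modest but beyond the scatter, and it involves the same group on the carbonyl carbon, with the larger 2-methylprop-1-en-1-yl going with the lower number. For the measured compounds named here, it is a single pair, though, and it changes a different carbon, and no measured compound carries a longer chain. A smaller step in the same direction, towards a lower number in this assay, is therefore expected, and it may not clear the scatter. The expected change is a 1.7-fold lower number from compound 3 to compound 4 (0.23 log units; within the scatter). For compound 4 the estimate is 2500 nM, with an expected range from 800 nM to 7000 nM.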

Compound 4, half-maximal inhibitory concentration: 57 nM
For compound 4 the middle estimate is 44-fold (1.64 log units) above the measured one; measured number below the stated range.
By their numbers in this assay, from the lowest: compound 4; then compounds 2 and 1 (each within the scatter of the next); then compound 3.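

In this assay, among the compounds shown here, extending the chain on the carbonyl carbon from prop-1-en-1-yl to pent-1-en-1-yl gives a 75-fold lower number from compound 3 to compound 4 (1.87 log units; beyond the scatter) and so shows that this position can shift the number much further than the only earlier step, a 5.4-fold higher number from compound 2 to compound 3 (0.73 log units; beyond the scatter) and a modest one, had suggested. The gain is not simply a matter of adding carbon to this group, since pent-1-en-1-yl also outperforms 2-methylprop-1-en-1-yl, with a 14-fold lower number from compound 2 to compound 4 (1.14 log units; beyond the scatter) and both steps well beyond the scatter, so that among these three compounds, which differ only in this group, compound 4 carries the lowest number. Nothing shown here accounts for the size of these steps, and their cause remains unknown.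

The compounds shown leave open whether a still longer chain, such as hept-1-en-1-yl, would lower the number further or raise it again, and whether an amine at the end of the chain would preserve the effect. They also leave open whether pent-1-en-1-yl would produce a similar step on the core of compound 1, which differs from compound 4 in more than one place.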